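Hydrazone series: shifting the chloro substituent

The compounds below may be only part of what the source reports. "The series", "measured", "known", "first", "only" and "open" are said of these compounds alone.

Measured so far:
compound 1 `O=C(N/N=C/c1cccc(F)c1)c1cccnc1Nc1cccc(C(F)(F)F)c1`: 37%
compound 2 `O=C(N/N=C/c1cccc(Cl)c1)c1cccnc1Nc1cccc(C(F)(F)F)c1`: 55.2%

In a functional assay on the whole organism (strain Wistar) for inhibition, with Rattus norvegicus as the target, read by paw edema, with a stated time of 3 h, at a dose of 10 mg/kg by the intraperitoneal route (on this read-out lower numbers stand for less inhibition and higher numbers for more inhibition at the one dose given (going by the name of the read-out)), compound 2 stands highest of the two numbers; compound 1 is nearest, sitting lower by a number 18.2 percentage points higher from compound 1 to compound 2 (beyond the scatter). Compound 3 `O=C(N/N=C/c1ccc(Cl)cc1)c1cccnc1Nc1cccc(C(F)(F)F)c1` keeps the atoms of compound 2 joined differently: 4-chlorophenyl in place of 3-chlorophenyl on a carbon with a double bond to nitrogen. Within the data shown here, the one measured step, a number 18.2 percentage points higher from compound 1 to compound 2 (beyond the scatter), swaps the halogen at an unchanged place and does not bear on moving the chlorine; no measured step informs this change. The expected step is therefore none beyond the scatter, a number 3.2 percentage points lower from compound 2 to compound 3 (within the scatter), with wide bounds. Compound 3 is estimated at 52%, between 36% and 68%.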

Compound 3, a percentage reported as inhibition, in the whole organism at one dose (the size of the read-out at that dose, not a potency): 48.5%
For compound 3 the middle estimate is 3.5 percentage points above the measured one; measured number inside the range.
By their numbers in this assay, from the lowest: compound 1; then compounds 3 and 2 (each within the scatter of the next).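

In this assay, 4-chlorophenyl in place of 3-chlorophenyl on a carbon with a double bond to nitrogen gives a number 6.7 percentage points lower from compound 2 to compound 3 (within the scatter), so the two chlorophenyl compounds cannot be told apart at this dose. The 3-fluorophenyl compound remains separate from both, and the step to the new compound is a number 11.5 percentage points higher from compound 1 to compound 3 (beyond the scatter). Nothing available accounts for these numbers.

Open, as far as these compounds go, is whether an amine or a carboxylic acid in place of the chlorine would keep the inhibition of the chlorophenyl compounds. The read-out at one dose also leaves open how these compounds compare at other doses.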